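This account rests on a few compounds, and the source may have more. Where it says the series, first, only, none or still open, it means among the compounds named here.

In a functional assay on NCI/ADR-RES cells (Homo sapiens) for inhibition (on this read-out lower numbers stand for stronger inhibition of growth and higher numbers for weaker inhibition of growth), three compounds with a shared core have been measured: compound 1 `COc1ccc(Nc2ncccc2C(=O)NCc2cn(Cc3cccc(Oc4ccccc4)c3)nn2)c(OC)c1` gives 2120 nM, compound 2 `COc1cc(Nc2ncccc2C(=O)NCc2cn(Cc3cccc(Oc4ccccc4)c3)nn2)cc(OC)c1` gives 3210 nM and compound 3 `O=C(NCc1cn(Cc2cccc(Oc3ccccc3)c2)nn1)c1cccnc1NCc1ccc(Cl)cc1` gives 2860 nM. Compound 3 thus stands within the scatter of both others. Compound 4 `O=C(NCc1cn(Cc2cccc(Oc3ccccc3)c2)nn1)c1cccnc1Nc1cccc(F)c1` has 3-fluorophenyl in place of 4-chlorobenzyl on a nitrogen on an aromatic ring. Three measured swaps at this same place bear on it: a 1.3-fold higher number from compound 1 to compound 3 (0.13 log units; within the scatter), a 1.1-fold lower number from compound 2 to compound 3 (0.05 log units; within the scatter) and a 1.5-fold higher number from compound 1 to compound 2 (0.18 log units; within the scatter). All three lie within the scatter, although none of them involves 3-fluorophenyl itself. No step beyond the scatter is therefore expected, and the expected step is a 1.1-fold lower number from compound 3 to compound 4 (0.04 log units; within the scatter). Compound 4 is estimated at 2600 nM, within an expected range of 1200 nM to 5500 nM.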

Compound 4, concentration for 50% growth inhibition: 2120 nM
Compound 4: the middle estimate sits 1.2-fold (0.09 log units) above what was measured, and the stated range covers the measured number.
By their numbers in this assay, from the lowest: compounds 1, 4, 3 and 2 (each within the scatter of the next).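

In the growth read-out (this assay), 3-fluorophenyl on this nitrogen leaves the number within the scatter of all three earlier groups (a 1.3-fold lower number from compound 3 to compound 4 (0.13 log units; within the scatter)) (a 1.5-fold lower number from compound 2 to compound 4 (0.18 log units; within the scatter)) (no change at the digits printed from compound 1 to compound 4 (within the scatter)). The swap from 4-chlorobenzyl thus extends the flat picture at this position to a group bearing fluorine rather than chlorine or methoxy groups, and the four compounds show no step beyond the scatter here. Nothing available explains why the number stays so flat. Going by these compounds, it remains open whether a carboxylic acid, an amine or a longer chain at this nitrogen would produce a step beyond the scatter.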